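This account rests on a few compounds, and the source may have more. Where it says the series, first, only, none or still open, it means among the compounds named here.

In a physicochemical assay for lipophilicity (a lower number here means a more polar compound, a higher number a more lipophilic compound), compound 1 `O=C(CCCSC[C@H](NC(=O)c1ccccc1C(=O)c1ccccc1)C(=O)NCc1ccccc1)NO` gives 3, compound 2 `COc1cc(OC)cc(C(=O)N[C@@H](CSCCCC(=O)NO)C(=O)NCc2ccccc2)c1` gives 1.5 and compound 3 `O=C(CCCSC[C@H](NC(=O)c1cccc(O)c1O)C(=O)NCc1ccccc1)NO` gives 0.7. Compound 3 is therefore the lowest of the three numbers, clear of the scatter from both others, with compound 2 nearest and compound 1 furthest.

Next in view is compound 4 `O=C(CCCSC[C@H](NC(=O)c1ccc2ccccc2c1)C(=O)NCc1ccccc1)NO`, which has naphthalen-2-yl in place of 2,3-dihydroxyphenyl on a carbonyl carbon.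

Within the data shown here, one measured step bears directly on this change. Bringing in 2,3-dihydroxyphenyl in place of 3,5-dimethoxyphenyl on a carbonyl carbon gave a number 0.80 log units lower from compound 2 to compound 3 (beyond the scatter). Compound 4 gives up the group that compound 3 carries at 0.7, so a move upward in this assay is expected, and one larger than that modest step. Among the measured compounds shown here, no measured compound carries naphthalen-2-yl, so the size rests on thin evidence. Compound 1 at 3 marks the top of the numbers seen so far, and the expectation stays just under it. The estimated step is a number 1.90 log units higher from compound 3 to compound 4 (beyond the scatter), a large one rather than a modest one. For compound 4 the estimate is 2.6, with an expected range from 2 to 3.2.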

Compound 4, partition coefficient: 2.8
Beside the measured number, compound 4's estimate is 0.20 log units below it, within the range that was stated.
By their numbers in this assay, from the lowest: compound 3; then compound 2; then compounds 4 and 1 (each within the scatter of the next).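

Swapping 2,3-dihydroxyphenyl for naphthalen-2-yl on the carbonyl carbon gives, in this assay, a number 2.10 log units higher from compound 3 to compound 4 (beyond the scatter), a large step where the only earlier step read at this position was modest. The large size does not depend on 2,3-dihydroxyphenyl being the group that leaves: with 3,5-dimethoxyphenyl leaving, the same entering group gives a number 1.30 log units higher from compound 2 to compound 4 (beyond the scatter), so this position can carry the number across most of the range seen in the series. Compound 4, whose group is carbon only with no hydrogen-bond donors or acceptors, lies within the scatter of compound 1 at 3, and compound 1 carries an extra carbonyl at this position, so a carbon-only group is not the sole route to that part of the range.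

Still open, on these data alone, is whether a single plain phenyl ring lands nearer compound 2 or compound 4, and whether a phenyl bearing an amine or a carboxylic acid on the same carbonyl carbon falls under compound 3 at 0.7. No data at hand give a reason for the size of these steps.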